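Piperazine aryl ketones: amide side-chain variation and expected affinity

The source may report more compounds than this note shows. Statements on the series, on what has been measured and on what is new or still open speak of the compounds shown alone.

Two members of the series have been measured. Compound 1 `CC(C)(C)OC[C@@H](N)C(=O)N1CCN(CCCOc2ccc(C(=O)C3CC3)cc2)CC1` gives, in an assay for binding affinity to histamine H2 receptor (Homo sapiens) (a higher number here means a weaker inhibitor, a lower number a stronger inhibitor), 45700 nM. Compound 2 `CCCCCC(=O)c1ccc(OCCCN2CCN(C(=O)[C@@H](C)N)CC2)cc1` gives in this assay 40700 nM. For the measured compounds named here, the two numbers sit within the scatter of each other, so neither compound can be called the weaker on this evidence; both sit at the high end of the measured range, and no step between them can be drawn, since the two structures differ in more than one place.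

Compound 3 `CN[C@@H](C(=O)N1CCN(CCCOc2ccc(C(=O)C3CC3)cc2)CC1)C(C)C` remains to be measured. Relative to compound 1 it carries 2-methyl-1-(methylamino)propyl in place of 1-amino-2-(tert-butoxy)ethyl on a carbonyl carbon. This is a change confined to the substituent on the amide carbonyl, with the shared core and the aryl ketone untouched. Nothing in the measured pair shows how such a change moves the number.

The expectation is that the step of a 1.2-fold lower number from compound 1 to compound 3 (0.08 log units; within the scatter) stays within the scatter, with no direction that can be defended from the two values shown. Compound 3 is therefore estimated at 38000 nM in this assay, with a range from 12000 nM to 110000 nM.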

Compound 3, inhibition constant: 49000 nM
For compound 3 the middle estimate is 1.3-fold (0.11 log units) below the measured one, and the stated range covers the measured number.
By their numbers in this assay, from the lowest: compounds 2, 1 and 3 (each within the scatter of the next).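

For the compounds shown here, on the carbonyl carbon whose other neighbours are the amide-type nitrogen in a ring, 2-methyl-1-(methylamino)propyl in place of 1-amino-2-(tert-butoxy)ethyl gives the first step that can be read (a 1.1-fold higher number from compound 1 to compound 3 (0.03 log units; within the scatter)) in this assay and the two compounds cannot be told apart. The group that leaves has 8 heavy atoms and 2 hydrogen-bond acceptors and the group that enters has 6 heavy atoms and 1 hydrogen-bond acceptor, yet for this one pair that difference in counts comes with no difference in the number beyond the scatter. No independent measurement is available to account for this result.

One step at this position cannot show whether the number here responds to the substituent at all, and a side chain ending in a carboxylic acid or carrying a phenyl ring would test that on the core of compound 3. The effect of the group on the ketone also stays unresolved, since compound 2 differs from both other compounds in more than one place and a cyclopropyl-to-pentyl exchange cannot be read on its own.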